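The source may hold more compounds than are shown below. What is called first, only, known or untested is meant among the compounds shown, and "the series" means these compounds.

compound 1 `COc1ccc(C(=O)Oc2cc3c(cc2C)[C@@H](C(C)C)CC=C3C)cc1`: 18.6%
compound 2 `Cc1cc2c(C(C)C)ccc(C)c2cc1OC(=O)c1cccc(C(F)(F)F)c1`: 17.3%
compound 3 `CC1=CC[C@H](C(C)C)c2cc(C)c(OC(=O)c3cccc(C)c3)cc21`: "not active" (no number reported)

All three share one core and differ only in the aromatic ester. In a functional assay on SK-LU-1 cells (Homo sapiens) for antiproliferative activity, read by sulforhodamine B assay, with a stated time of 48 h, tested at 50 uM (a higher number here means more inhibition at the concentration tested (going by the name of the read-out), a lower number less inhibition), compound 1 gives 18.6% and compound 2 gives 17.3%; these two numbers lie within the usual scatter of each other, so the inhibition in this assay is level between them. Compound 3 is reported as "not active" (no number reported), with no number attached.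

Compound 4 `CC1=CC[C@H](C(C)C)c2cc(C)c(OC(=O)c3ccc(Cl)cc3)cc21` has not yet been measured. It differs from compound 1 in one place: chloro in place of methoxy on an aromatic carbon. Within the data shown here, no measured pair shows the effect of exactly this change, and every number seen so far is low, so the step from compound 1 to compound 4 is expected to stay within the scatter, leaning if anything slightly downward. Compound 4 is expected to give 15%, with a range from 0% to 32%. The expected step is a number 3.6 percentage points lower from compound 1 to compound 4 (within the scatter).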

Compound 4, a percentage reported as inhibition, at one concentration (the size of the read-out at that concentration, not a potency): 17.4%
For compound 4 the middle estimate is 2.4 percentage points below the measured one; the range from low to high includes it.
By their numbers in this assay, from the lowest: compounds 2, 4 and 1 (each within the scatter of the next).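

In this assay chloro in place of methoxy gives a number 1.2 percentage points lower from compound 1 to compound 4 (within the scatter) and so the inhibition stays level at this position, on an aromatic carbon of the ester's ring. Among these compounds, this is the first pair differing in one place, and it shows that losing the methoxy group's hydrogen-bond acceptor and one heavy atom brings no readable change here. No measurement at hand says why the two groups read alike.

Going by these compounds, whether an amine or a carboxylic acid on this same carbon would move the inhibition stays open. So does whether any ester on the shared core can rise clearly above these low readings.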